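Cell tolerance when a basic amine gives way to an alcohol

The source may hold more compounds than are shown below. What is called first, only, known or untested is meant among the compounds shown, and "the series" means these compounds.

Compound 1 `c1ccc(-c2nc3ccccn3c2Nc2ccc3c(c2)OCCO3)nc1` — 25600 nM
Compound 2 `CN(C)CCNc1c(-c2ccccn2)nc2ccccn12` — > 50000 nM

In an ADME assay on THP-1 cells (Homo sapiens) for cytotoxicity (a higher number here means that more compound is tolerated, a lower number that less compound is tolerated), compound 1 gives 25600 nM. For compound 2 the assay returns only a limit, > 50000 nM, so its true value is not known, only that it lies past that point. Of the two numbers shown, one therefore sits at the edge of the measurable range: the limit of > 50000 nM in this assay, at which 1 of the 2 values shown sits. Compound 1 sits within the measured range, and the two compounds share no single-point change, so what is known is merely that both are tolerated at high concentration.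

Compound 3 `CC(C)(O)CNc1c(-c2ccccn2)nc2ccccn12` is to be measured in this assay. It differs from compound 2 in one place: 1-hydroxy-1-methylethyl in place of (dimethylamino)methyl on a saturated chain carbon bound to a nitrogen on an aromatic ring. Among the compounds with values here, no measured pair shows this exact change, so the expectation rests on compound 2 alone. Since compound 2 already stands at the limit, the step from compound 2 to compound 3 is expected to be a step that the limit leaves unreadable from compound 2 to compound 3, that is, no change beyond the usual scatter. Compound 3 is thus expected to give about 60000 nM, within a range from 25000 nM to 150000 nM, and most likely again only a limit.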

Compound 3, half-maximal cytotoxic concentration: > 50000 nM
Compound 3: only a limit was reported (the forecaster's own chance of this, stated with the estimate: 70%); the middle value lies beyond the limit too.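

In this assay, within the data shown here, compound 3 returns only a limit, as compound 2 does, so no step between compound 2 and compound 3 can be read, because both stop at the same edge of the range: the limit of > 50000 nM in this assay, at which 2 of the 3 values shown sit. The compounds shown leave open how far past that limit each one lies, and so whether 1-hydroxy-1-methylethyl in place of (dimethylamino)methyl alters cell tolerance at all.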